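Moving the ring substituent: compound 2 to compound 3

A few compounds are considered here, and "the series" means these few. Any claim that something is new, unique, unknown or untested is made for them only; others in the source may bear on it.

The series measures oral exposure in an ADME assay on the whole organism for pharmacokinetics, with Rattus norvegicus as the target, at a dose of 5 mg/kg by the oral route; on this read-out higher numbers stand for higher oral bioavailability and lower numbers for lower oral bioavailability. Compound 1 `CO[C@H]1CC[C@H](N2CC(=O)Nc3ncc(-c4ccc(C(C)(C)O)nc4)nc32)CC1` gives 70% in this assay. Compound 2 `CC(C)(O)c1ccc(-c2cnc3c(n2)N(CCC2CCOCC2)C(=O)CN3)cn1` gives 58% in this assay, the lowest of the two numbers shown; its nearest neighbour is compound 1, whose number lies higher by a margin beyond the usual scatter. Among the measured compounds shown here, no pair of measured compounds differs in only one place, so no single-change step is available to calibrate the next move.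

Compound 3 `CO[C@H]1CC[C@H](N2C(=O)CNc3ncc(-c4ccc(C(C)(C)O)nc4)nc32)CC1` has the same atoms as compound 2, joined differently: 4-methoxycyclohexyl in place of 2-(oxan-4-yl)ethyl on an amide-type nitrogen in a ring. Without a measured step of this kind, the size of the move is uncertain. Given that compound 1, the only other measured compound, gives 70% in this assay, an upward step from the value of compound 2 appears plausible, though it may also stay within the scatter. The step from compound 2 to compound 3 is expected to be a number 7 percentage points higher from compound 2 to compound 3 (within the scatter). Compound 3 is therefore estimated to give 65% in this assay, with a range from 45% to 85%.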

Compound 3, oral bioavailability: 59%
Beside the measured number, compound 3's estimate is 6 percentage points above it; the measured number falls inside the stated range.
By their numbers in this assay, from the lowest: compounds 2 and 3 (each within the scatter of the next); then compound 1.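

The step gives the series its first single-change reading: in this assay, 4-methoxycyclohexyl in place of 2-(oxan-4-yl)ethyl on an amide-type nitrogen in a ring amounts to a number 1 percentage points higher from compound 2 to compound 3 (within the scatter). At this position, therefore, the read-out does not separate a carbon-only six-membered ring that carries two defined stereocentres from a six-membered ring with one hetero atom, at least for these two groups, which match in heavy atoms, hydrogen-bond donors and hydrogen-bond acceptors as counted. No measurement on hand explains this result.

On these data alone, what remains open is whether a group of a different kind at this position, such as an amine, a carboxylic acid or a longer chain, would shift oral bioavailability beyond the usual scatter, since both groups seen here are neutral and match in size. Among the compounds shown here, it also remains open how the other stereoisomer of 4-methoxycyclohexyl would behave in this assay, and no single-change step connects compound 1 to either of the other two compounds.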